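Swapping a Spiro Amine for Piperazine: Effect on Lipophilicity

The compounds below may be only part of what the source reports. "The series", "measured", "known", "first", "only" and "open" are said of these compounds alone.

Compound 1 `CN1CC2(C1)CN(c1ccc(OCc3ccccc3)c(C(=O)Nc3ccnnc3)c1)C2` — 2
Compound 2 `O=C(Nc1cccc(Cl)c1)c1cc(C(F)(F)F)ccc1OCc1ccc(F)cc1` — 8.7
Compound 3 `N#Cc1cccc(NC(=O)c2cc(C(F)(F)F)ccc2OCc2ccc(F)cc2)c1` — 7.5

The three measured compounds were tested in a physicochemical assay for lipophilicity, at pH 7.4; a higher number here means a more lipophilic compound, a lower number a more polar compound. Compound 1 stands lowest of the three: compound 3 lies well above it, and compound 2 lies further above still, both gaps far beyond the scatter. Going by the values given here, compound 2 and compound 3 share a core and differ only in one group; the step of a number 1.20 log units lower from compound 2 to compound 3 (beyond the scatter) is the single step measured between neighbouring compounds.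

Compound 4 `O=C(Nc1ccnnc1)c1cc(N2CCNCC2)ccc1OCc1ccccc1` has not yet been measured. It differs from compound 1 in one place: a group of 6 heavy atoms (4 carbon, 2 nitrogen; one six-membered non-aromatic ring with 2 hetero atoms) in place of a group of 8 heavy atoms (6 carbon, 2 nitrogen; 2 four-membered non-aromatic rings with 1 hetero atom each), on an aromatic carbon.

Among the compounds with values here, no measured step covers this kind of change. Within the data shown here, the one step that exists concerns an exchange of cyano for chloro on a core that compound 1 and compound 4 do not share, so it gives no direct guidance for the size or direction here. The expectation therefore rests mainly on the value of compound 1 itself, with a wide range to reflect the lack of a matching step. The expected step is a number 0.50 log units lower from compound 1 to compound 4 (beyond the scatter), a modest change that may not clear the scatter. Compound 4 is estimated at 1.5, between 0.5 and 2.8.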

Compound 4, distribution coefficient: 1.9
Beside the measured number, compound 4's estimate is 0.40 log units below it; measured number inside the range.
By their numbers in this assay, from the lowest: compounds 4 and 1 (each within the scatter of the next); then compound 3; then compound 2.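

At this position, para to a benzyloxy group and meta to a (pyridazin-4-yl)carbamoyl group, this assay gives a number 0.10 log units lower from compound 1 to compound 4 (within the scatter) when piperazin-1-yl replaces the group with two four-membered rings. This change brings a group of 6 heavy atoms and 1 hydrogen-bond donor in place of one of 8 heavy atoms and no donor, yet the two compounds cannot be told apart in this measurement, something the earlier cyano and chloro pair could not show. Nothing available bears on why the number holds at this position.

Open still is how other groups on this carbon would read, such as a morpholine ring or an open-chain dimethylamino group. On these data alone, this is also a single pair on one core, so the same exchange on a different core remains unknown.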